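The compounds below may be only part of what the source reports. "The series", "measured", "known", "first", "only" and "open" are said of these compounds alone.

Measured compounds in a functional assay on KOPN-8 cells (Homo sapiens) for antiproliferative activity, with a stated time of 72 h; a higher number here means that more compound is needed for the effect, a lower number that less compound is needed:
- compound 1 `COc1ccc(-c2cc(=O)c3c(OC)cc(OC)cc3n2S(=O)(=O)c2ccc([N+](=O)[O-])cc2)cc1` gives 17300 nM
- compound 2 `COc1ccc(-c2cc(=O)c3c(OC)cc(OC)cc3n2S(=O)(=O)c2cc(F)c(F)c(F)c2)cc1` gives only a limit, > 65500 nM

Compound 2 stands at the edge of what this assay can report: its value is a limit, not a number, and compound 2 is the one of the two that sits at the limit of > 65500 nM in this assay, at which 1 of the 2 values shown sits. For the measured compounds named here, the step of an at least 3.7-fold higher number from compound 1 to compound 2 (0.57 log units; beyond the scatter) is the only measured change on the sulfonyl sulfur, and it points toward weaker activity when the group there is changed. Compound 3 `COc1ccc(-c2cc(=O)c3c(OC)cc(OC)cc3n2S(=O)(=O)c2cc(Cl)cc(Cl)c2O)cc1` carries a further change at that same place: 3,5-dichloro-2-hydroxyphenyl in place of 3,4,5-trifluorophenyl on a sulfonyl sulfur. Going by the values given here, no measured step pairs this new group with either of the others, so the direction for compound 3 is uncertain; the one step that exists suggests this position is sensitive. Compound 3 is therefore expected to land roughly where compound 2 does, with a wide spread, a step of an at least 1.4-fold lower number from compound 2 to compound 3 (0.16 log units; that floor lies within the scatter) meaning an estimate of 45000 nM (range 8000 nM to 200000 nM) in this assay.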

Compound 3, half-maximal effective concentration: > 37900 nM
Compound 3: only a limit was reported (the forecaster's own chance of this, stated with the estimate: 50%); the middle value does not contradict the limit.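

In this assay compound 3 also gives only a limit, > 37900 nM, so a second replacement for 4-nitrophenyl on the sulfonyl sulfur now stands at the edge of what this read-out can report: the limit of > 37900 nM in this assay, at which 1 of the 3 values shown sits. Putting 3,5-dichloro-2-hydroxyphenyl in place of 4-nitrophenyl gives an at least 2.1-fold higher number from compound 1 to compound 3 (0.34 log units; beyond the scatter), so two differently substituted rings now both need more compound than 4-nitrophenyl does. The step between compound 2 and compound 3 cannot be read from two limits, and neither of their groups can be placed ahead of the other.

Still open, on these data alone, is whether the nitro group itself matters, which a 4-aminophenyl or 4-cyanophenyl group on the sulfonyl sulfur could test. Also open, as far as these compounds go, is whether a group without a ring there, such as a methyl or a longer alkyl chain, would give a true number rather than a limit.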